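A few compounds are considered here, and "the series" means these few. Any claim that something is new, unique, unknown or untested is made for them only; others in the source may bear on it.

Of the compounds shown here, two have been measured in a physicochemical assay for lipophilicity, using the shake flask method, at pH 7.4; on this read-out lower numbers stand for lower lipophilicity and higher numbers for higher lipophilicity. Compound 1 `CC(=O)N1CCN([C@H]2CC[C@H](Nc3ncnn4ccc([C@H]5CC[C@H](C(N)=O)CC5)c34)CC2)CC1` gives 1.4 in this assay. For the measured compounds named here, compound 2 `CN(C)[C@H]1CC[C@H](Nc2ncnn3ccc(C4CCOCC4)c23)CC1` gives 0.5 in this assay, the lower of the two numbers, with compound 1 standing higher by a margin beyond the usual scatter; the two differ in more than one place, so no single step connects them.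

Compound 3 `CC(=O)N1CCN([C@H]2CC[C@H](Nc3ncnn4ccc(C5CCOCC5)c34)CC2)CC1` has not yet been measured in this assay. It differs from compound 2 in one place: 4-acetylpiperazin-1-yl in place of dimethylamino on a saturated ring carbon.

Because compound 1, which carries the same 4-acetylpiperazin-1-yl group on its saturated ring carbon, gives 1.4, compound 3 is expected to land well above compound 2. The step from compound 2 to compound 3 is expected to be a number 0.90 log units higher from compound 2 to compound 3 (beyond the scatter), an upward step beyond the scatter. For compound 3 the estimate in this assay is 1.4, within a range from 0.9 to 1.9.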

Compound 3, distribution coefficient: 1.6
Beside the measured number, compound 3's estimate is 0.20 log units below it; low and high end bracket the measured number.
By their numbers in this assay, from the lowest: compound 2; then compounds 1 and 3 (each within the scatter of the next).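

At the saturated ring carbon, 4-acetylpiperazin-1-yl in place of dimethylamino gives a number 1.10 log units higher from compound 2 to compound 3 (beyond the scatter) in this assay, the first single-place step measured at this position. On the aromatic carbon, oxan-4-yl in place of 4-carbamoylcyclohexyl gives a number 0.20 log units higher from compound 1 to compound 3 (within the scatter), so this exchange, with 4-acetylpiperazin-1-yl held constant, leaves the two compounds within the usual scatter of each other. No measurement available here explains either step.

The compounds shown leave open whether the large step belongs to the acetyl group or to the ring that carries it, which a plain piperazine or a morpholine at the same carbon could separate. They also leave open whether dimethylamino gives a similar number when 4-carbamoylcyclohexyl sits on the aromatic carbon.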